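The compounds below may be only part of what the source reports. "The series", "measured", "known", "first", "only" and "open" are said of these compounds alone.

Measured compounds:
compound 1 `OCc1cnn(-c2nc(Nc3ccc(C(F)(F)F)cc3)c3ncn([C@@H]4O[C@H](CO)[C@@H](O)[C@H]4O)c3n2)c1` — > 6000 nM
compound 2 `CCOC(=O)c1cnn(-c2nc(NC3CCCCC3)c3ncn([C@@H]4O[C@H](CO)[C@@H](O)[C@H]4O)c3n2)c1` — > 6000 nM

In an in vitro assay on HEK293 cells for displacement of a labelled ligand from adenosine receptor A2b (Homo sapiens) (on this read-out higher numbers stand for weaker inhibition and lower numbers for stronger inhibition), compound 1 gives > 6000 nM, which is a limit of the assay rather than a measured number. Compound 2 likewise returns only a limit, > 6000 nM. Compound 1 therefore cannot be placed on any scale of potency: everything known so far is the limit of > 6000 nM in this assay, at which 2 of the 2 values shown sit.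

Compound 3 `Cc1ccc(Nc2nc(-n3cc(CO)cn3)nc3c2ncn3[C@@H]2O[C@H](CO)[C@@H](O)[C@H]2O)cc1` is the next case, and it differs from compound 1 in one place, methyl in place of trifluoromethyl on an aromatic carbon — methyl in place of trifluoromethyl on an aromatic carbon, so that the (4-(trifluoromethyl)phenyl)amino of compound 1 becomes a (4-methylphenyl)amino. Going by the values given here, no measured pair shows what such a change does in this assay, so the direction of the step is open. Because compound 1 itself sits at the limit of > 6000 nM in this assay, at which 2 of the 2 values shown sit, compound 3 is expected to stay weak, most likely again beyond the limit, with an estimated step that the limit leaves unreadable from compound 1 to compound 3. Compound 3 is thus estimated at 9000 nM, within 2500 nM to 40000 nM.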

Compound 3, inhibition constant: > 6000 nM
Compound 3 ended at the assay's limit; the forecaster's own chance of this, stated with the estimate: 75%; the middle value does not contradict the limit.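

Going by these compounds alone, compound 1 and compound 3 both stand only as limits in this assay, so no step between them can be read. The compounds shown leave open what methyl in place of trifluoromethyl does, and how their potencies compare, with all known so far being: the limit of > 6000 nM in this assay, at which 3 of the 3 values shown sit.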